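Fluoro on the benzyl ring: compound 3 to compound 4

The compounds below may be only part of what the source reports. "The series", "measured", "known", "first", "only" and "open" are said of these compounds alone.

Of the compounds shown here, three sharing a common core have been tested in a functional assay on MNK45 cells (Homo sapiens) for inhibition, read by MTT assay, with a stated time of 48 h; on this read-out lower numbers stand for stronger inhibition and higher numbers for weaker inhibition. Compound 1 `Cc1ccc(NC(=S)NC(=O)c2ccc(OCc3ccc(Cl)cc3Cl)cc2)cc1-c1nc2ccccc2[nH]1` gives 5300 nM, and compound 2 `O=C(NC(=S)Nc1ccc(Cl)c(-c2nc3ccccc3[nH]2)c1)c1ccc(OCc2ccc(Cl)c(Cl)c2)cc1` gives 4600 nM. Compound 3 `Cc1ccc(NC(=O)NC(=O)c2ccc(OCc3ccccc3)cc2)cc1-c1nc2ccccc2[nH]1` gives 35100 nM, the highest of the three numbers, with compound 1 the nearest and compound 2 the furthest, both gaps beyond the scatter. Compounds 1 and 2 differ from compound 3 in more than one place, so their values show only where each stands, not what any single change does.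

Compound 4 `Cc1ccc(NC(=O)NC(=O)c2ccc(OCc3ccccc3F)cc2)cc1-c1nc2ccccc2[nH]1` is not yet measured. It differs from compound 3 in one place: fluoro in place of hydrogen on an aromatic carbon. For the measured compounds named here, a single added fluorine is a small change, and with no measured pair of this kind to lean on, the expectation is a modest step from compound 3 to compound 4 in this assay, of a 1.4-fold lower number from compound 3 to compound 4 (0.15 log units; within the scatter), most likely toward a somewhat lower number but possibly within the scatter. For compound 4 the estimated value in this assay is 25000 nM, with a plausible range from 10000 nM to 60000 nM.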

Compound 4, half-maximal inhibitory concentration: 1830 nM
Beside the measured number, compound 4's estimate is 14-fold (1.14 log units) above it; the whole stated range lies above it.
By their numbers in this assay, from the lowest: compound 4; then compounds 2 and 1 (each within the scatter of the next); then compound 3.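

In this assay, the change from benzyl to 2-fluorobenzyl gives a 19-fold lower number from compound 3 to compound 4 (1.28 log units; beyond the scatter), so one added heavy atom on this ring, ortho to a large group, is enough to move the number well beyond the scatter. For the compounds shown here, this is the first matched pair: the earlier compounds differed from one another in more than one place and could show only where each stood, whereas this pair isolates a single change and shows that this position on the benzyl ring strongly affects the read-out, even though the change itself is small. Nothing available explains why so small a change has so large an effect, and the size of the step alone cannot supply a reason.

The compounds shown leave open whether this step is specific to fluoro, since no pair tests a methoxy, a nitrile or a trifluoromethyl group on the same carbon. They also leave open whether fluoro on another carbon of the benzyl ring would give a step of similar size, or whether this one would carry over to a different core.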